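The source may report more compounds than this note shows. Statements on the series, on what has been measured and on what is new or still open speak of the compounds shown alone.

Values in (a functional assay on A549 cells (Homo sapiens) for antiproliferative activity, read by MTT assay, with a stated time of 48 h; a lower number here means a stronger inhibitor, a higher number a weaker inhibitor):
- compound 1 (`COc1ccc(-c2cn3cc(C4=CCN(S(=O)(=O)CCc5ccccc5)CC4)ccc3n2)cc1OC`) gives 7690 nM
- compound 2 (`COc1ccc(-c2cn3cc(C4=CCN(C(=O)c5ccccc5C(F)(F)F)CC4)ccc3n2)cc1OC`) gives 2550 nM
- compound 3 (`COc1ccc(-c2cn3cc(C4=CCN(C(=O)C(C)(C)C)CC4)ccc3n2)cc1OC`) gives 4340 nM

The number for compound 3 falls inside the span set by compound 1 and compound 2 and lies within the scatter of each (a 1.7-fold higher number from compound 2 to compound 3 (0.23 log units; within the scatter); a 1.8-fold lower number from compound 1 to compound 3 (0.25 log units; within the scatter)). Next in the series is compound 4 (`COc1ccc(-c2cn3cc(C4=CCN(S(=O)(=O)C5CCCCC5)CC4)ccc3n2)cc1OC`), which carries cyclohexylsulfonyl in place of (tert-butyl)carbonyl on an amine nitrogen in a ring. Within the data shown here, no measured compound carries cyclohexylsulfonyl, so the estimate rests on indirect comparisons. The closest is the exchange between phenethylsulfonyl and (tert-butyl)carbonyl (a 1.8-fold lower number from compound 1 to compound 3 (0.25 log units; within the scatter)), which stays within the scatter and, read backwards, points weakly towards a higher number for a sulfonyl group. Among the measured compounds shown here, the only step beyond the scatter is modest (a 3.0-fold lower number from compound 1 to compound 2 (0.48 log units; beyond the scatter)) and involves (2-(trifluoromethyl)phenyl)carbonyl, which plays no part in the present change. A small rise in this assay is therefore expected, with no step beyond the scatter. The expected change is a 1.3-fold higher number from compound 3 to compound 4 (0.10 log units; within the scatter) and is estimated to remain within the scatter. For compound 4 the estimated value is 5500 nM (expected range 2500 nM to 12000 nM).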

Compound 4, half-maximal inhibitory concentration: 4490 nM
For compound 4 the middle estimate is 1.2-fold (0.09 log units) above the measured one; low and high end bracket the measured number.
By their numbers in this assay, from the lowest: compounds 2, 3, 4 and 1 (each within the scatter of the next, the first and the last beyond it).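

In this assay, cyclohexylsulfonyl and (tert-butyl)carbonyl on the amine nitrogen in a ring cannot be told apart (a 1.0-fold higher number from compound 3 to compound 4 (0.01 log units; within the scatter)), so this pair separates neither a sulfonyl from a carbonyl link nor a group with one six-membered non-aromatic ring of carbon only from one with no ring. Among these compounds, compound 4 also gives the first comparison of two groups on a sulfonyl sulfur, where cyclohexyl and phenethyl stay within the scatter (a 1.7-fold lower number from compound 1 to compound 4 (0.23 log units; within the scatter)), and it stays within the scatter of the aryl amide as well (a 1.8-fold higher number from compound 2 to compound 4 (0.25 log units; within the scatter)), even though compound 1 and compound 2 are separated beyond the scatter (a 3.0-fold lower number from compound 1 to compound 2 (0.48 log units; beyond the scatter)). Nothing at hand accounts for these close readings at the nitrogen.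

The compounds shown leave open whether a group on this nitrogen with an amine or a carboxylic acid at its end would move the number beyond the scatter from compound 3. Also open, on these data alone, is whether a methyl or a longer chain on the sulfonyl sulfur would read like cyclohexyl and phenethyl.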